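Urea-linked thienopyrimidines: fluoro for methyl on the phenyl

The source may hold more compounds than are shown below. What is called first, only, known or untested is meant among the compounds shown, and "the series" means these compounds.

Measured so far:
Compound 1, `Cc1ccc(NC(=O)Nc2nnc(Sc3ncnc4scc(-c5ccncc5)c34)s2)cc1Cl`: 16000 nM
Compound 2, `Cc1ccc(NC(=O)Nc2nnc(Sc3ncnc4scc(-c5ccncc5)c34)s2)cc1`: 52000 nM

Compound 1 and compound 2 were tested in a functional assay on HepG2 cells (Homo sapiens) for antiproliferative activity, read by MTT assay, with a stated time of 48 h; on this read-out higher numbers stand for weaker inhibition and lower numbers for stronger inhibition. Within the data shown here, compound 2 stands at the highest of the two numbers; its nearest neighbour is compound 1, and the one measured step, a 3.3-fold higher number from compound 1 to compound 2 (0.51 log units; beyond the scatter), is a modest rise in the number when hydrogen replaces chloro on an aromatic carbon.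

Compound 3, `O=C(Nc1ccc(F)cc1)Nc1nnc(Sc2ncnc3scc(-c4ccncc4)c23)s1`, differs from compound 2 by fluoro in place of methyl on an aromatic carbon; at one bond further out this reads 4-methylphenyl to 4-fluorophenyl, on an aromatic carbon of a six-membered aromatic ring of carbon only, para to a large group. Among the measured compounds shown here, no measured step covers a methyl-to-fluoro exchange; the only step, a 3.3-fold higher number from compound 1 to compound 2 (0.51 log units; beyond the scatter), concerns a different halogen at a different place on the same ring, so it bears on it only loosely. A small step is therefore expected for compound 3, a 1.3-fold lower number from compound 2 to compound 3 (0.11 log units; within the scatter), with no firm direction. Compound 3 is estimated at 40000 nM, within 15000 nM to 110000 nM.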

Compound 3, half-maximal inhibitory concentration: 31700 nM
The estimate for compound 3 lay 1.3-fold (0.10 log units) above the measured number, within the range that was stated.
By their numbers in this assay, from the lowest: compounds 1, 3 and 2 (each within the scatter of the next, the first and the last beyond it).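

In this assay, fluoro on the aromatic carbon para to a large group gives a 1.6-fold lower number from compound 2 to compound 3 (0.21 log units; within the scatter), so at this place the two small groups cannot be told apart. The wider exchange gives a 2.0-fold higher number from compound 1 to compound 3 (0.30 log units; within the scatter), which places compound 3 within the scatter of both compound 1 and compound 2, even though those two stand apart by a 3.3-fold higher number from compound 1 to compound 2 (0.51 log units; beyond the scatter). Nothing measured on these compounds bears on why the numbers fall as they do.

Going by these compounds, whether a methoxy, an amine or a carboxylic acid at this place would shift the number beyond the scatter stays open. So does what chloro would give at this place, with no other group on the ring.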